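Swapping Hydroxy for Anilino on Compound 1

A few compounds are considered here, and "the series" means these few. Any claim that something is new, unique, unknown or untested is made for them only; others in the source may bear on it.

Among the measured compounds shown here, in a functional assay on KB cells (Homo sapiens) for inhibition, read by MTT assay, with a stated time of 24 h, tested at 0.1 ug/mL (a lower number here means less inhibition of growth, a higher number more inhibition of growth at the concentration tested), compound 1 (`CC(=O)SCCC(CCCCC(=O)O)SC(C)=O`) gives 7.24%, the only number available so far. Compound 2 (`O=C(CCCCC(S)CCS)Nc1ccccn1`) is reported as "not active" (no number reported). Compound 3 (`CC(=O)SCCC(CCCCC(=O)Nc1ccccc1)SC(C)=O`) keeps the core of compound 1 but carries anilino in place of hydroxy on a carbonyl carbon. For the measured compounds named here, no measured pair shows this change, so the expectation is only a small upward move, within the usual scatter. The expected change is a number 4.8 percentage points higher from compound 1 to compound 3 (within the scatter). For compound 3, the estimated value in this assay is 12%, with a range from 2% to 30%.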

Compound 3, percent growth inhibition at one concentration: 7.24%
Estimate against measurement, compound 3: 4.8 percentage points above; the measured number falls inside the stated range.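

In this assay there is no change at the digits printed from compound 1 to compound 3 (within the scatter) when anilino takes the place of hydroxy on a carbonyl carbon. This first measured pair at this place shows that the much larger anilino group, with its six-membered aromatic ring, leaves the reading at this one concentration unmoved. No measurement available here offers an explanation for this result. Going by these compounds, whether a methoxy group or a simple amine on the same carbonyl carbon would move the number remains open. So does the behaviour of these compounds at higher concentrations.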